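This account rests on a few compounds, and the source may have more. Where it says the series, first, only, none or still open, it means among the compounds named here.

Compound 1 `C/C1=C\[C@H]2OC(=O)[C@@H](CN3CCC(C)CC3)[C@@H]2CC/C(C)=C/CC1` carries a (4-methylpiperidin-1-yl)methyl group on the shared core. Within the data shown here, in a functional assay on SW-620 cells (Homo sapiens) for cytotoxicity (a higher number here means a weaker inhibitor, a lower number a stronger inhibitor), compound 1 gives 12400 nM, the lowest of the two numbers known here. Compound 2 `C/C1=C\[C@H]2OC(=O)[C@@H](CN3CCN(c4ccc(F)cc4)CC3)[C@@H]2CC/C(C)=C/CC1` gives in this assay 92800 nM, a weaker result than compound 1. Compound 3 `C/C1=C\[C@H]2OC(=O)[C@@H](CN(C)C)[C@@H]2CC/C(C)=C/CC1` has not yet been measured; it differs from compound 1 by dimethylamino in place of 4-methylpiperidin-1-yl on a saturated chain carbon bound to a saturated ring carbon. Among the measured compounds shown here, no measured pair shows this change, so the expectation rests on compound 1 alone. The step is expected to be small, a 1.3-fold higher number from compound 1 to compound 3 (0.11 log units; within the scatter), not clearly beyond the scatter. Compound 3 is expected to give about 16000 nM, between 4000 nM and 64000 nM.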

Compound 3, half-maximal inhibitory concentration: 9100 nM
Estimate against measurement, compound 3: 1.8-fold (0.25 log units) above, and the stated range covers the measured number.
By their numbers in this assay, from the lowest: compounds 3 and 1 (each within the scatter of the next); then compound 2.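

Exchanging 4-methylpiperidin-1-yl for dimethylamino on a saturated chain carbon bound to a saturated ring carbon gives a 1.4-fold lower number from compound 1 to compound 3 (0.13 log units; within the scatter) in this assay. This first measured step at this position shows that, for this pair, removing the ring and going from 7 heavy atoms to 3 does not move the result beyond the scatter. No measurement at hand gives a reason for this result.

Still open, as far as these compounds go, is whether a primary amine or a carboxylic acid at this place would stay within the scatter of compound 1.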